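Compound 3: dropping the (4-aminophenyl)carbamoyl group

A few compounds are considered here, and "the series" means these few. Any claim that something is new, unique, unknown or untested is made for them only; others in the source may bear on it.

Measured in a functional assay on KB cells (Homo sapiens) for antiproliferative activity, read by sulforhodamine B assay, with a stated time of 48 h; on this read-out higher numbers stand for weaker inhibition of growth and lower numbers for stronger inhibition of growth:
Compound 1 `COc1ccc(S(=O)(=O)Nc2ccccc2CCc2ccc(C(=O)Nc3ccccc3)cc2)cc1`: 137 nM
Compound 2 `COc1ccc(S(=O)(=O)Nc2ccccc2CCc2ccc(C(=O)Nc3ccc(N)cc3)cc2)cc1`: 286 nM

For the measured compounds named here, compound 2, at 286 nM, carries the higher of the two numbers so far, and compound 1 gives 137 nM. Next comes compound 3 `COc1ccc(S(=O)(=O)Nc2ccccc2CCc2ccccc2)cc1`, which differs from compound 2 as follows: hydrogen in place of (4-aminophenyl)carbamoyl on an aromatic carbon. In words, hydrogen stands in place of (4-aminophenyl)carbamoyl on an aromatic carbon, para to a large group. Going by the values given here, only one measured step bears on this: a 2.1-fold higher number from compound 1 to compound 2 (0.32 log units; beyond the scatter). It is modest and involves only amino in place of hydrogen, on the ring that leaves here, so it is a weak guide to losing the whole group. Among the compounds with values here, no measured compound lacks that group, so direction and size remain uncertain. A larger step toward a higher number in this assay is expected, estimated as a 5.2-fold higher number from compound 2 to compound 3 (0.72 log units; beyond the scatter). The estimate for compound 3 is 1500 nM, with an expected range of 250 nM to 9000 nM.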

Compound 3, concentration for 50% growth inhibition: 4410 nM
Beside the measured number, compound 3's estimate is 2.9-fold (0.47 log units) below it; the measured number falls inside the stated range.
By their numbers in this assay, from the lowest: compound 1; then compound 2; then compound 3.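

In this assay, hydrogen in place of the whole group gives a 15-fold higher number from compound 2 to compound 3 (1.19 log units; beyond the scatter) and hydrogen in place of phenylcarbamoyl gives a 32-fold higher number from compound 1 to compound 3 (1.51 log units; beyond the scatter) as the two large steps, while the earlier amino change on the ring that leaves gave only a 2.1-fold higher number from compound 1 to compound 2 (0.32 log units; beyond the scatter) as a modest one. Among these three compounds, then, the presence of either amide-linked group at this aromatic carbon goes with much stronger inhibition of growth, and the change on its outer ring matters far less than its complete removal. No measurement shown accounts for the size of these steps.

A primary carboxamide or a carboxylic acid at this aromatic carbon would show whether the carbonyl alone recovers the lost inhibition or the outer ring is also needed. Going by these compounds, how far the outer ring tolerates other groups, such as methoxy or chlorine in place of the amino group, also stays open.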